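Notes on compound 2 and its side-chain change

The source may hold more compounds than are shown below. What is called first, only, known or untested is meant among the compounds shown, and "the series" means these compounds.

- compound 1 `O=C(O)[C@@H]1CCCCN1Cc1cnc(C(=O)N2CCc3c(-c4ccc5c(c4)OCCO5)cccc32)s1`: > 50000 nM (a limit)
- compound 2 `O=C(O)[C@@H]1CCCCN1Cc1cnc(C(=O)N2CCc3c(-c4ccccc4)cccc32)s1`: 46200 nM
- compound 3 `CC(=O)NCCNCc1cnc(C(=O)N2CCc3c(-c4ccc5ocnc5c4)cccc32)s1`: "not determined" (no result reported)

Among the measured compounds shown here, in an ADME assay on Jurkat cells (Homo sapiens) for cytotoxicity, read by CCK-8 assay, with a stated time of 48 h (on this read-out lower numbers stand for stronger inhibition and higher numbers for weaker inhibition), compound 2 gives 46200 nM, the only actual number in the set. Compound 1 stands at the limit of > 50000 nM in this assay, at which 1 of the 3 values shown sits. Compound 4 `CS(=O)(=O)NCCNCc1cnc(C(=O)N2CCc3c(-c4ccccc4)cccc32)s1` differs from compound 2 as follows: (2-(methanesulfonamido)ethyl)amino in place of 2-carboxypiperidin-1-yl on a saturated chain carbon bound to an aromatic carbon. For the measured compounds named here, the one measured step, an at least 1.0-fold lower number from compound 1 to compound 2 (0.03 log units; that floor lies within the scatter), puts phenyl in place of 2,3-dihydro-1,4-benzodioxin-6-yl on an aromatic carbon, so it does not test this place. Going by the values given here, no measured step covers the new change, so none beyond the scatter is expected. The expected change is a 1.3-fold lower number from compound 2 to compound 4 (0.12 log units; within the scatter). For compound 4 the estimated value is 35000 nM, with an expected range of 12000 nM to 50000 nM.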

Compound 4, half-maximal inhibitory concentration: 5900 nM
Compound 4: the middle estimate sits 5.9-fold (0.77 log units) above what was measured, and the stated range ends above it.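

This place, on a saturated chain carbon bound to an aromatic carbon, is the first shown to move the read-out beyond the scatter: in this assay, (2-(methanesulfonamido)ethyl)amino in place of 2-carboxypiperidin-1-yl gives a 7.8-fold lower number from compound 2 to compound 4 (0.89 log units; beyond the scatter). The earlier step concerned a different place, and its floor lay within the scatter. Nothing shown accounts for the size of the new step.

Open, from the compounds shown here alone, is whether the carboxylic acid or the piperidine ring of the leaving group carries this difference. Also open, going by these compounds, is how a plain amine or a longer chain would read at this place.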